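Swapping the aryl sulfonyl of compound 3 for a pyrrolidine amide

This account rests on a few compounds, and the source may have more. Where it says the series, first, only, none or still open, it means among the compounds named here.

Three compounds have been measured in an assay on isolated protein for displacement of a labelled ligand from secreted frizzled-related protein 1 (Homo sapiens), read by fluorescence polarization, with a stated time of 30 min; on this read-out higher numbers stand for weaker inhibition and lower numbers for stronger inhibition:
compound 1 `O=C(c1ccc(Cl)cc1)N1CCC(NS(=O)(=O)c2cc(S(=O)(=O)c3ccccc3)ccc2C(F)(F)F)CC1` gives 300 nM
compound 2 `O=C(c1cccnc1)N1CCC(NS(=O)(=O)c2cc(S(=O)(=O)c3ccccc3)ccc2C(F)(F)F)CC1` gives 80 nM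
compound 3 `N#Cc1cccc(S(=O)(=O)N2CCC(NS(=O)(=O)c3cc(S(=O)(=O)c4ccccc4)ccc3C(F)(F)F)CC2)c1` gives 90 nM

Compound 3 stands second highest of the three numbers. Its nearest neighbour is compound 2, and the two lie within the scatter of each other; compound 1 is furthest away, the step from compound 1 to compound 3 being a 3.3-fold lower number from compound 1 to compound 3 (0.52 log units; beyond the scatter).

Compound 4 `O=C([C@H]1CCNC1)N1CCC(NS(=O)(=O)c2cc(S(=O)(=O)c3ccccc3)ccc2C(F)(F)F)CC1` differs from compound 3 in one place: (pyrrolidin-3-yl)carbonyl in place of (3-cyanophenyl)sulfonyl on an amine nitrogen in a ring. The measured steps that touch this position are a 3.8-fold lower number from compound 1 to compound 2 (0.57 log units; beyond the scatter), a 3.3-fold lower number from compound 1 to compound 3 (0.52 log units; beyond the scatter) and a 1.1-fold higher number from compound 2 to compound 3 (0.05 log units; within the scatter). Each of them exchanges one aromatic group for another on the same ring nitrogen, and none tests a non-aromatic ring carrying a hydrogen-bond donor, so they are only a loose guide. They show that a group at this position can shift the number by a modest amount, and the present change is structurally larger than any of them. Compound 4 is therefore expected to show a modest step to a higher number, a 2.2-fold higher number from compound 3 to compound 4 (0.35 log units; beyond the scatter), with wide uncertainty. The estimate for compound 4 is 200 nM, with a range from 60 nM to 700 nM.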

Compound 4, half-maximal inhibitory concentration: 40 nM
For compound 4 the middle estimate is 5.0-fold (0.70 log units) above the measured one; the whole stated range lies above it.
By their numbers in this assay, from the lowest: compounds 4, 2 and 3 (each within the scatter of the next, the first and the last beyond it); then compound 1.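

In this assay, the position on the amine nitrogen in a ring proves not to depend on an aromatic ring: (pyrrolidin-3-yl)carbonyl, a five-membered non-aromatic ring with fewer heavy atoms than the group it replaces and with a hydrogen-bond donor, gives a 2.3-fold lower number from compound 3 to compound 4 (0.35 log units; beyond the scatter). On the same carbonyl carbon, the exchange of pyridin-3-yl for pyrrolidin-3-yl gives a 2.0-fold lower number from compound 2 to compound 4 (0.30 log units; within the scatter), so these two groups cannot be told apart here, whereas the exchange of 4-chlorophenyl for pyrrolidin-3-yl gives a 7.5-fold lower number from compound 1 to compound 4 (0.88 log units; beyond the scatter), the largest step seen so far at this position. Nothing available explains how the entering group produces this result.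

From the compounds shown here alone, it remains open whether the ring nitrogen of the pyrrolidine matters at all, a question that a cyclopentyl group or a 1-methylpyrrolidin-3-yl group on the same carbonyl would address. The contribution of the defined stereocentre is also unsettled, and the mirror-image pyrrolidin-3-yl group would be the direct comparison.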